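The source may report more compounds than this note shows. Statements on the series, on what has been measured and on what is new or still open speak of the compounds shown alone.

Compound 1 `O=C(Nc1cccc(Nc2ncc(F)c(Nc3ccc(F)cc3)n2)c1)c1cnccn1`, compound 2 `O=C(c1cccc(Nc2ncc(F)c(Nc3ccc(F)cc3)n2)c1)N1CCCCC1` and compound 3 `O=C(Nc1cccc(Nc2ncc(F)c(Nc3ccc(F)cc3)n2)c1)c1ccccc1` share one core. In a functional assay on KBVIN cells (Homo sapiens) for antiproliferative activity, read by sulforhodamine B assay, with a stated time of 3 days (on this read-out lower numbers stand for stronger inhibition of growth and higher numbers for weaker inhibition of growth), compound 1 gives 20100 nM and compound 2 gives 13800 nM. Compound 3 gives > 10000 nM, which is a limit of the assay and not a number. Compound 4 `O=C(Nc1cc(Cl)cc(Cl)c1)c1cccc(Nc2ncc(F)c(Nc3ccc(F)cc3)n2)c1` differs from it by (3,5-dichlorophenyl)carbamoyl in place of benzamido on an aromatic carbon. For the measured compounds named here, the one readable step, a 1.5-fold lower number from compound 1 to compound 2 (0.16 log units; within the scatter), is also an exchange on an aromatic carbon. The others, a step that the limit leaves unreadable from compound 1 to compound 3 and a step that the limit leaves unreadable from compound 2 to compound 3, give no size. On that single step of compound 2, no change beyond the scatter is expected in this assay, in either direction. The step expected is a number no higher from compound 3 to compound 4 (the limit leaves the size open). The estimate for compound 4 is 10000 nM, with an expected range of 3000 nM to 25000 nM.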

Compound 4, concentration for 50% growth inhibition: 20700 nM
Compound 4: the middle estimate sits 2.1-fold (0.32 log units) below what was measured, and the stated range covers the measured number.
By their numbers in this assay, from the lowest: compounds 2, 1 and 4 (each within the scatter of the next).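

Compound 4 places (3,5-dichlorophenyl)carbamoyl on this aromatic carbon and, in this assay, stays level with both other compounds that give a number (a 1.5-fold higher number from compound 2 to compound 4 (0.18 log units; within the scatter)) and (a 1.0-fold higher number from compound 1 to compound 4 (0.01 log units; within the scatter)). Three different groups at this place therefore show no change beyond the scatter, even with the two chlorine atoms on the added ring. Compound 3 stands at a limit, and every step to it cannot be read: (the limit of > 10000 nM in this assay, at which 1 of the 4 values shown sits).

Going by these compounds, whether a dimethylamino group or a carboxylic acid at this place would move the number beyond the scatter stays open.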